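Acetoxy to hydroxy: the next step from compound 2

The source may hold more compounds than are shown below. What is called first, only, known or untested is meant among the compounds shown, and "the series" means these compounds.

In a functional assay on ASK cells (Rattus norvegicus) for cytotoxicity, read by sulforhodamine B assay (a lower number here means that less compound is needed, a higher number that more compound is needed for the effect), compound 1 `C=C1CC[C@@H]2[C@](C)(CO)[C@H](OC(C)=O)CC[C@@]2(C)[C@@H]1C/C=C1/C(=O)OC[C@H]1OC(C)=O` gives 11.5 uM and compound 2 `C=C1CC[C@@H]2[C@](C)(CO[Si](C)(C)C(C)(C)C)[C@H](OC(C)=O)CC[C@@]2(C)[C@@H]1C/C=C1/C(=O)OC[C@H]1OC(C)=O` gives 1.22 uM, the lower of the two numbers. Compound 3 `C=C1CC[C@@H]2[C@](C)(CO[Si](C)(C)C(C)(C)C)[C@H](O)CC[C@@]2(C)[C@@H]1C/C=C1/C(=O)OC[C@H]1OC(C)=O` differs from compound 2 by hydrogen in place of acetyl on an oxygen on a saturated carbon, acetoxy to hydroxy. Within the data shown here, no measured step removes an acetyl. The nearest evidence is a 9.4-fold lower number from compound 1 to compound 2 (0.97 log units; beyond the scatter), where a hydrogen on a different oxygen was replaced. Hydrogen now returns on an oxygen, so a modest rise in this assay is expected, though this analogy is loose. The expected change is a 2.5-fold higher number from compound 2 to compound 3 (0.39 log units; beyond the scatter). For compound 3 the estimated value is 3 uM, with an expected range of 1 uM to 9 uM.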

Compound 3, concentration for half-maximal effect: 3.41 uM
Beside the measured number, compound 3's estimate is 1.1-fold (0.06 log units) below it, within the range that was stated.
By their numbers in this assay, from the lowest: compound 2; then compound 3; then compound 1.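

In this assay, among these compounds, the first change at this oxygen gives a 2.8-fold higher number from compound 2 to compound 3 (0.45 log units; beyond the scatter), so the acetyl on this position does affect the number, and its loss moves the number up. Even so, with the hydroxy in place, compound 3 still reads 3.41 uM. No available evidence accounts for the size or direction of this step. The compounds shown leave open how a methyl ether, a benzoyl ester or an amine would read on this carbon. They also leave open whether removing the acetyl gives a similar step when the other oxygen carries a hydrogen.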